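This account rests on a few compounds, and the source may have more. Where it says the series, first, only, none or still open, it means among the compounds named here.

Compound 1 (`O=C1O/C(=C\Cn2cnc3c(F)nc(F)c(Cl)c32)C(OCc2ccccc2)=C1OCc1ccccc1`) gives 55000 nM in a functional assay on SW-620 cells (Homo sapiens) for antiproliferative activity, read by MTT assay, with a stated time of 72 h (on this read-out lower numbers stand for stronger inhibition and higher numbers for weaker inhibition), and lies within the scatter of both other measured compounds. Compound 2 (`O=C1O/C(=C\Cn2cnc3ccn(C/C=C4\OC(=O)C(OCc5ccccc5)=C4OCc4ccccc4)c3c2=O)C(OCc2ccccc2)=C1OCc1ccccc1`) gives 47200 nM and compound 3 (`O=C1NC(O)(CCn2cnc3cc[nH]c3c2=O)C(OCc2ccccc2)=C1OCc1ccccc1`) gives 90700 nM in this assay as well. Compound 4 (`O=C1O/C(=C\Cn2cnc3cc[nH]c3c2=O)C(OCc2ccccc2)=C1OCc1ccccc1`) differs from compound 1 by a group of 10 heavy atoms (6 carbon, 3 nitrogen, 1 oxygen; one five-membered aromatic ring with 1 hetero atom, one six-membered aromatic ring with 2 hetero atoms) in place of a group of 12 heavy atoms (6 carbon, 3 nitrogen, 2 fluorine, 1 chlorine; one five-membered aromatic ring with 2 hetero atoms, one six-membered aromatic ring with 1 hetero atom), on a saturated chain carbon bound to a double-bonded chain carbon and is otherwise the same. Going by the values given here, no measured pair isolates this change. Compound 2 also carries a different group on that chain and, at 47200 nM, stays within the scatter of compound 1, so no step beyond the scatter is expected in this assay here. The estimated step (a 1.1-fold lower number from compound 1 to compound 4 (0.04 log units; within the scatter)) stays within the scatter. Compound 4 is expected at 50000 nM (estimated range 20000 nM to 100000 nM).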

Compound 4, half-maximal inhibitory concentration: > 100000 nM
Compound 4: no number, only a limit; the forecaster's own chance of this, stated with the estimate: 10%; middle value at least 2.0-fold (0.30 log units) from the limit.
By their numbers in this assay, from the lowest: compounds 2, 1 and 3 (each within the scatter of the next). At a limit, above all of these: compound 4.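

In this assay compound 4 gives only a limit, > 100000 nM, and not a number. The group of 10 heavy atoms in place of the group of 12 heavy atoms, on the saturated chain carbon, gives an at least 1.8-fold higher number from compound 1 to compound 4 (0.25 log units; that floor lies within the scatter), so this first direct reading of the change shows no gain, while its floor shows no loss beyond the scatter.

As far as these compounds go, how large the step really is stays open, and the fluorine and chlorine atoms leave together, so their separate shares cannot be read. From the compounds shown here alone, what an amine on the shared core or a longer chain in that place would give also stays open.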